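Swapping an Imidazole for a Dimethylaminophenyl Group

This account rests on a few compounds, and the source may have more. Where it says the series, first, only, none or still open, it means among the compounds named here.

Measured compounds:
compound 1 `Cc1nccn1CC(/C(=N/OC(=O)Nc1cccc(Cl)c1)C1CCCCC1)C1CCCCC1` — > 1000 nM
compound 2 `O=C(Nc1cccc(F)c1)O/N=C(\C1CCCCC1)C(Cc1cccs1)C1CCCCC1` — 12.3 nM

In an assay on isolated protein for displacement of a labelled ligand from metabotropic glutamate receptor 5 (Rattus norvegicus) (on this read-out higher numbers stand for weaker inhibition and lower numbers for stronger inhibition), compound 1 gives > 1000 nM, which is a limit of the assay and not a number. Compound 2, which carries a thiophene-bearing side chain and a fluorine on its carbamate ring, gives 12.3 nM in this assay. No pair of these compounds differs in only one place, so no single measured step can be read off; compound 1 simply sits at the limit of > 1000 nM in this assay, at which 1 of the 2 values shown sits.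

Compound 3 `CN(C)c1ccc(CC(/C(=N/OC(=O)Nc2cccc(Cl)c2)C2CCCCC2)C2CCCCC2)cc1` has not been measured. It differs from compound 1 by 4-(dimethylamino)phenyl in place of 2-methyl-1H-imidazol-1-yl on a saturated chain carbon, two bonds along the chain from a carbon with a double bond to nitrogen and a saturated ring carbon. Because compound 1 stands only at the limit of > 1000 nM in this assay, at which 1 of the 2 values shown sits, the step to compound 3 cannot be compared with a measured one. The expectation is that compound 3 binds more strongly, an estimated step of an at least 6.6-fold lower number from compound 1 to compound 3 (0.82 log units; beyond the scatter) toward tighter inhibition. Compound 3 is thus expected to give about 150 nM in this assay, with a range from 25 nM to 1000 nM.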

Compound 3, inhibition constant: > 1000 nM
Compound 3 gave a limit, no number; the forecaster's own chance of this, stated with the estimate: 20%; at least 6.6-fold (0.82 log units) between middle value and limit.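

Compound 1 and compound 3 both stand at a limit of the measurement, not at a number, so no step between them can be read: the limit of > 1000 nM in this assay, at which 2 of the 3 values shown sit.

Still open, going by these compounds, is whether 4-(dimethylamino)phenyl in compound 3 binds any differently from 2-methyl-1H-imidazol-1-yl in compound 1.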